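The source may hold more compounds than are shown below. What is called first, only, known or untested is meant among the compounds shown, and "the series" means these compounds.

Going by the values given here, compound 1 `COc1cc(C(=O)/C=C/c2cn(-c3ccccc3)nc2-c2ccsc2)cc(OC)c1OC` is one of two compounds measured in a functional assay on MCF7 cells (Homo sapiens) for inhibition, read by sulforhodamine B assay, with a stated time of 72 h (on this read-out higher numbers stand for weaker inhibition and lower numbers for stronger inhibition), where compound 1 gives 4900 nM. Compound 2 `COc1ccc(C(=O)/C=C/c2cn(-c3ccccc3)nc2-c2ccsc2)cc1OC` gives 2800 nM in this assay, and the step of a 1.8-fold lower number from compound 1 to compound 2 (0.24 log units; within the scatter) stays within the scatter. Compound 3 `COc1cc(C(=O)/C=C/c2cn(-c3ccccc3)nc2-c2cccnc2)cc(OC)c1OC` carries pyridin-3-yl in place of thiophen-3-yl on an aromatic carbon. Among the compounds with values here, no measured step touches this ring; the only step in hand concerns a methoxy group elsewhere and was within the scatter, so nothing indicates a change beyond the scatter for compound 3 in this assay. Compound 3 is therefore expected near 4900 nM, between 1500 nM and 16000 nM, which means an expected step of no change at the digits printed from compound 1 to compound 3 (within the scatter).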

Compound 3, half-maximal inhibitory concentration: 14500 nM
For compound 3 the middle estimate is 3.0-fold (0.47 log units) below the measured one; low and high end bracket the measured number.
By their numbers in this assay, from the lowest: compounds 2 and 1 (each within the scatter of the next); then compound 3.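

Going by these compounds alone, the only step at this position, on an aromatic carbon of the five-membered ring with 2 nitrogen, is beyond the scatter in this assay: a 3.0-fold higher number from compound 1 to compound 3 (0.47 log units; beyond the scatter). The number therefore responds to the ring at this position, a modest change, whereas a 1.8-fold lower number from compound 1 to compound 2 (0.24 log units; within the scatter), at the methoxy group elsewhere, does not leave the scatter. Nothing available accounts for the shift. From the compounds shown here alone, whether ring size or the hetero atom goes with the higher number stays open, and furan-3-yl or thiophen-2-yl at this position would bear on that.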